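Swapping the amide substituent in a cinnamate ester series

The source may hold more compounds than are shown below. What is called first, only, known or untested is meant among the compounds shown, and "the series" means these compounds.

Measured compounds:
Compound 1, `COCOc1cc(/C=C/C(=O)OCC(=O)Nc2ccc(Cl)cc2)ccc1OCc1ccccc1`: > 200000 nM in a functional assay on LS174T cells (Homo sapiens) for cytotoxicity, read by MTT assay, with a stated time of 72 h; a higher number here means a weaker inhibitor, a lower number a stronger inhibitor
Compound 2, `COCOc1cc(/C=C/C(=O)OCC(=O)Nc2nccs2)ccc1OCc1ccccc1`: > 200000 nM

Compound 1 carries a 4-chlorophenyl on the amide-type nitrogen, and in this assay compound 1 reaches only the assay limit of > 200000 nM rather than a number. Compound 2 carries a 1,3-thiazol-2-yl there, and compound 2 likewise stops at the limit of > 200000 nM. The step that the two limits leave unreadable from compound 1 to compound 2 therefore cannot be read, because both values sit at the limit (the limit of > 200000 nM in this assay, at which 2 of the 2 values shown sit). Compound 2 thus stands nowhere better than the least sensitive end of what this assay can report.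

Compound 3, `COCOc1cc(/C=C/C(=O)OCC(=O)NCc2ccco2)ccc1OCc1ccccc1`, is not yet measured. It differs from compound 2 by (furan-2-yl)methyl in place of 1,3-thiazol-2-yl on an amide-type nitrogen. Within the data shown here, the single measured step gives no size and no direction to build on. Compound 3 is expected to remain at the limit, with an estimate of 200000 nM ranging from 60000 nM to 600000 nM, meaning an expected step of a number no higher from compound 2 to compound 3 (the limit leaves the size open).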

Compound 3, half-maximal inhibitory concentration: > 200000 nM
Compound 3: no number, only a limit (the forecaster's own chance of this, stated with the estimate: 85%); the middle value sits exactly at the limit.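

Among these compounds, no step among compound 1, compound 2 and compound 3 can be read, because each gives a limit rather than a number: the limit of > 200000 nM in this assay, at which 3 of the 3 values shown sit. The compounds shown leave open which substituent on the amide-type nitrogen, if any, would give a measurable value in this assay.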